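The source may report more compounds than this note shows. Statements on the series, on what has been measured and on what is new or still open speak of the compounds shown alone.

Two close analogues of one shared core are in hand. Compound 1 `COc1ccc(-c2c(C#N)c(N)nc(SCc3csc(-c4ccc(Br)cc4)n3)c2C#N)cc1` gives 3.8 nM in an assay on CHO cells for displacement of a labelled ligand from adenosine receptor A1 (Homo sapiens); a higher number here means a weaker inhibitor, a lower number a stronger inhibitor. Compound 2 `COc1ccc(-c2c(C#N)c(N)nc(SCc3csc(-c4ccc(Cl)cn4)n3)c2C#N)cc1` gives 24 nM in this assay. For the measured compounds named here, the single step between them, a 6.3-fold higher number from compound 1 to compound 2 (0.80 log units; beyond the scatter), is the only comparison so far, and it places compound 2 at the higher of the two numbers, with compound 1 as its only neighbour.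

The next compound, compound 3 `COc1ccc(-c2c(C#N)c(N)nc(SCc3csc(-c4ccc(F)cc4)n3)c2C#N)cc1`, differs from compound 2 in one place: 4-fluorophenyl in place of 5-chloropyridin-2-yl on an aromatic carbon. This returns the group at that position to a six-membered aromatic ring of carbon only, the same ring type compound 1 carries, with the halogen changed from bromine to fluorine. Going by the values given here, the measured step that bears on the change is the one from compound 1 to compound 2, which was beyond the scatter. Reversing the ring type is therefore expected to move the number back down; the halogen swap has no measured counterpart here, so the full size of that return is uncertain. The expected step is a 4.0-fold lower number from compound 2 to compound 3 (0.60 log units; beyond the scatter). In this assay compound 3 is estimated at 6 nM, within a range of 2 nM to 20 nM.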

Compound 3, inhibition constant: 2.3 nM
Estimate against measurement, compound 3: 2.6-fold (0.42 log units) above; the measured number falls inside the stated range.
By their numbers in this assay, from the lowest: compounds 3 and 1 (each within the scatter of the next); then compound 2.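

In this assay, going back to a ring of carbon only gives a 10-fold lower number from compound 2 to compound 3 (1.02 log units; beyond the scatter), so the number at compound 2 does not depend on carrying bromine in particular: with 4-fluorophenyl in this place on the five-membered ring, the number again stands well apart from that of the 5-chloropyridin-2-yl compound. The halogen swap on the carbon-only ring gives a 1.7-fold lower number from compound 1 to compound 3 (0.22 log units; within the scatter), so 4-bromophenyl and 4-fluorophenyl cannot be told apart here, and among these three compounds only the 5-chloropyridin-2-yl group stands out, with compound 2 at 24 nM. Nothing measured on these compounds accounts for this difference in the numbers.

The step to compound 2 changes the ring atom and the halogen together, so its size cannot yet be divided between the ring nitrogen and the chlorine; a 4-chlorophenyl or a 5-fluoropyridin-2-yl group in the same place would separate the two. On these data alone, it also remains open whether any halogen is needed on this ring, which an unsubstituted phenyl, or a ring bearing a methoxy group or an amine instead, would test.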